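The source may hold more compounds than are shown below. What is called first, only, known or untested is meant among the compounds shown, and "the series" means these compounds.

Compound 3, `COc1ccc(/C=C/c2cc(OC)cc(OC)c2/C=C/C(=O)c2ccc(N)cc2)cc1`, is one of three chalcones that share a core and differ only in the group on the benzoyl ring. In a functional assay on B16-F10 cells (Mus musculus) for antiproliferative activity, read by MTT assay, with a stated time of 48 h (on this read-out lower numbers stand for stronger inhibition and higher numbers for weaker inhibition), compound 3 gives 2.8 ug/mL, the lowest of the three numbers. Compound 1, `COc1ccc(/C=C/c2cc(OC)cc(OC)c2/C=C/C(=O)c2ccc(C)cc2)cc1`, gives 5.3 ug/mL, and compound 2, `COc1ccc(/C=C/c2cc(OC)cc(OC)c2/C=C/C(=O)c2ccc(C(F)(F)F)cc2)cc1`, gives 4.3 ug/mL; the steps of a 1.2-fold lower number from compound 1 to compound 2 (0.09 log units; within the scatter), a 1.9-fold lower number from compound 1 to compound 3 (0.28 log units; within the scatter) and a 1.5-fold lower number from compound 2 to compound 3 (0.19 log units; within the scatter) all lie within the scatter, so no order among the three can be read from these numbers.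

Compound 4, `COc1ccc(/C=C/c2cc(OC)cc(OC)c2/C=C/C(=O)c2ccc(OC)cc2)cc1`, carries the next variation at the same place: methoxy in place of amino on an aromatic carbon. Every measured step bears on this change, since each swaps one group for another on that same aromatic carbon, and none moved the number beyond the scatter. The reasonable expectation is therefore a step of no more than the scatter in this assay, in either direction.

Compound 4 is expected to give about 3.8 ug/mL, with a range from 1.9 ug/mL to 7.6 ug/mL, a step of a 1.4-fold higher number from compound 3 to compound 4 (0.13 log units; within the scatter) that is itself expected to stay within the scatter.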

Compound 4, half-maximal inhibitory concentration: 5.8 ug/mL
Compound 4: middle estimate off by 1.5-fold (0.18 log units), on the low side; the range from low to high includes it.
By their numbers in this assay, from the lowest: compounds 3, 2, 1 and 4 (each within the scatter of the next, the first and the last beyond it).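

In this assay, among these compounds, the change from amino to methoxy gives the first step at this aromatic carbon that lies beyond the scatter, a modest one: a 2.1-fold higher number from compound 3 to compound 4 (0.32 log units; beyond the scatter). The other two new steps stay within the scatter, a 1.3-fold higher number from compound 2 to compound 4 (0.13 log units; within the scatter) and a 1.1-fold higher number from compound 1 to compound 4 (0.04 log units; within the scatter), so methoxy cannot be told apart from trifluoromethyl or methyl here, and amino separates only from methoxy, since its steps to methyl and trifluoromethyl also stay within the scatter. Nothing shown explains the gap between amino and methoxy at this place.

The compounds shown leave open whether a hydroxyl, a dimethylamino group or an acetamide at this carbon would fall with amino or with methoxy. They also leave open whether the separation between compound 3 and compound 4 holds in any other cells.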